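Cyclopentyl to 3-chlorophenyl amine on the shared core

This account rests on a few compounds, and the source may have more. Where it says the series, first, only, none or still open, it means among the compounds named here.

Measured compounds:
compound 1 `O=C1C(NC2CCCC2)=CC(=O)c2c1nc1n2[C@H]2OC[C@@H](O)[C@H]2OC1`; in a functional assay on ECa-109 cells for inhibition, with ECa-109 cell line (Homo sapiens) as the target, read by sulforhodamine B assay (a higher number here means a weaker inhibitor, a lower number a stronger inhibitor), compound 1 gives > 16000 nM, which is a limit of the assay and not a number.
compound 2 `CCOc1ccc(NC2=CC(=O)c3nc4n(c3C2=O)[C@H]2OC[C@@H](O)[C@H]2OC4)cc1`; in this assay compound 2 gives 3210 nM.
compound 3 `O=C1C=C(Nc2cccc(Cl)c2)C(=O)c2c1nc1n2[C@H]2OC[C@@H](O)[C@H]2OC1`; in this assay compound 3 gives 4690 nM.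

For the measured compounds named here, compound 1 stands apart from the others only by the limit of > 16000 nM in this assay, at which 1 of the 3 values shown sits; no number is known for it, so no step from it can be sized. Compound 4 `O=C1C(Nc2cccc(Cl)c2)=CC(=O)c2c1nc1n2[C@H]2OC[C@@H](O)[C@H]2OC1` differs from compound 1 by 3-chlorophenyl in place of cyclopentyl on an amine nitrogen. Going by the values given here, the one measured step, a 1.5-fold higher number from compound 2 to compound 3 (0.16 log units; within the scatter), exchanges one aryl group for another and says nothing about replacing cyclopentyl by an aryl group. Compound 3 carries the same 3-chlorophenyl on the same kind of nitrogen, at a different carbon of the shared core, and its value together with that of compound 2 puts both aryl amines well inside the measurable range. Compound 4 is therefore expected to land near those two, at 5000 nM with a range of 1500 nM to 16000 nM. This estimate means a step of an at least 3.2-fold lower number from compound 1 to compound 4 (0.50 log units; beyond the scatter), counted from the limit of compound 1.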

Compound 4, half-maximal inhibitory concentration: 3080 nM
Compound 4: middle estimate off by 1.6-fold (0.21 log units), on the high side; measured number inside the range.
By their numbers in this assay, from the lowest: compounds 4, 2 and 3 (each within the scatter of the next). At a limit, above all of these: compound 1.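

On this amine nitrogen of the shared core, 3-chlorophenyl in place of cyclopentyl in this assay gives an at least 5.1-fold lower number from compound 1 to compound 4 (0.71 log units; beyond the scatter), the first sized change from a non-aromatic ring to an aromatic ring in the series. That size is only a minimum, as it is counted from a limit of the assay and not a number: the limit of > 16000 nM in this assay, at which 1 of the 4 values shown sits.

On these data alone, whether the change depends on the aromatic ring or on the chlorine remains open; unsubstituted phenyl on the same nitrogen would separate the two. Also open, as far as these compounds go, is how cyclohexyl or an open chain such as n-butyl behaves there.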